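Nitro for trifluoromethyl on the urea aryl ring

The compounds below may be only part of what the source reports. "The series", "measured", "known", "first", "only" and "open" are said of these compounds alone.

Measured so far:
compound 1, `CCC1(CC)CC(C)(C)Oc2ccc(NC(=O)Nc3ccc(C(F)(F)F)cc3)cc21`, 93.3%
compound 2, `CC1(C)CC(C)(C)c2cc(NC(=O)Nc3ccc(C(F)(F)F)cc3)ccc2O1`, 88.4%

In a functional assay on A2780 cells (Homo sapiens) for inhibition, with a stated time of 72 h, tested at 10 uM (on this read-out lower numbers stand for less inhibition of growth and higher numbers for more inhibition of growth at the one concentration tested), compound 1 gives 93.3%, the highest of the two numbers shown. Compound 2 gives 88.4%; the gap to compound 1 lies within the scatter, so the two values cannot be ordered. Both sit near the top of the read-out at the one concentration tested.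

Compound 3 `CCC1(CC)CC(C)(C)Oc2ccc(NC(=O)Nc3ccc([N+](=O)[O-])cc3)cc21` differs from compound 1 by nitro in place of trifluoromethyl on an aromatic carbon. For the measured compounds named here, no pair of measured compounds carries this change, so its size is not known from this set. Since compound 1 already stands at 93.3%, little room remains upward; the expected step of a number 8.3 percentage points lower from compound 1 to compound 3 (within the scatter) is small, downward if anything, and possibly none beyond the scatter. For compound 3 the estimate is 85%, between 65% and 97%.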

Compound 3, percent growth inhibition at one concentration: 93.7%
Beside the measured number, compound 3's estimate is 8.7 percentage points below it; measured number inside the range.
By their numbers in this assay, from the lowest: compounds 2, 1 and 3 (each within the scatter of the next).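

In this assay, nitro in place of trifluoromethyl on the aromatic carbon gives a number 0.4 percentage points higher from compound 1 to compound 3 (within the scatter) and so leaves the two compounds indistinguishable. For the compounds shown here, this is the first measured pair to differ in one place, and it shows that the position para to a large group can carry either group with growth inhibition still near the top of the read-out at the one concentration tested. Nothing measured here accounts for this result.

As far as these compounds go, with both compounds this close to the top at a single concentration, a real difference between them could stay hidden, so any ranking of the two groups remains open. Also open, from the compounds shown here alone, is whether an amine or a carboxylic acid at the same place would hold the read-out this high.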